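Dichlorophenyl for Trifluoromethylphenyl: an Expected Small Step

This account rests on a few compounds, and the source may have more. Where it says the series, first, only, none or still open, it means among the compounds named here.

Three compounds share one core and differ only in the aryl group on a nitrogen on an aromatic ring. In a functional assay on MGC-803 cells (Homo sapiens) for inhibition, read by MTT assay, with a stated time of 72 h (a higher number here means a weaker inhibitor, a lower number a stronger inhibitor), compound 1 `C=CC(=O)Nc1cccc(NC(=O)CSc2nc(Nc3ccccc3)c3ccccc3n2)c1` gives 7310 nM, compound 2 `C=CC(=O)Nc1cccc(NC(=O)CSc2nc(Nc3cccc(OC)c3)c3ccccc3n2)c1` gives 24200 nM, and compound 3 `C=CC(=O)Nc1cccc(NC(=O)CSc2nc(Nc3ccc(C(F)(F)F)cc3)c3ccccc3n2)c1` gives 12100 nM. Compound 3 holds the second highest of the three numbers; its nearest neighbour is compound 1, at a 1.7-fold higher number from compound 1 to compound 3 (0.22 log units; within the scatter), and its furthest is compound 2, at a 2.0-fold lower number from compound 2 to compound 3 (0.30 log units; within the scatter), both within the scatter. Among the compounds with values here, only the step of a 3.3-fold higher number from compound 1 to compound 2 (0.52 log units; beyond the scatter) lies beyond it.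

Compound 4 `C=CC(=O)Nc1cccc(NC(=O)CSc2nc(Nc3ccc(Cl)cc3Cl)c3ccccc3n2)c1` arises from compound 3 by 2,4-dichlorophenyl in place of 4-(trifluoromethyl)phenyl on a nitrogen on an aromatic ring. Within the data shown here, the steps that bear on this change are those that alter the same aryl group: from compound 1 to compound 3 and from compound 2 to compound 3, both within the scatter, while the methoxy step from compound 1 to compound 2 was modest. Since two of the three known changes on this aryl group left this assay barely moved, compound 4 is expected to show no step beyond the scatter, as a 1.3-fold lower number from compound 3 to compound 4 (0.13 log units; within the scatter). Compound 4 is therefore estimated at 9000 nM, within a range from 3500 nM to 25000 nM.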

Compound 4, half-maximal inhibitory concentration: 12100 nM
Estimate against measurement, compound 4: 1.3-fold (0.13 log units) below, within the range that was stated.
By their numbers in this assay, from the lowest: compounds 1, 3, 4 and 2 (each within the scatter of the next, the first and the last beyond it).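

In this assay, the 2,4-dichlorophenyl group on a nitrogen on an aromatic ring gives no change at the digits printed from compound 3 to compound 4 (within the scatter), which shows that this position can take an aryl group carrying two chlorine atoms, not only one with a single substituent, without a step beyond the scatter. Within the data shown here, the same group also gives a 1.7-fold higher number from compound 1 to compound 4 (0.22 log units; within the scatter) and a 2.0-fold lower number from compound 2 to compound 4 (0.30 log units; within the scatter), so compound 4 lies within the scatter of all three earlier compounds, even though those include the one pair that stands apart, a 3.3-fold higher number from compound 1 to compound 2 (0.52 log units; beyond the scatter). Among the four compounds, therefore, a change of aryl group at this place mostly leaves the number within the scatter, with only the pair of compound 1 and compound 2 going against this, and nothing shown here offers an explanation for either the agreement or the exception.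

The compounds shown leave open whether a carboxylic acid or a dimethylamino group on this aryl ring, or a cyclohexyl group in place of the ring, would produce a larger step. They also leave open whether a pyridyl ring here would behave like the aryl groups seen so far.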